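Methylsulfanyl for tert-butyl in two places: cytotoxicity

The source may report more compounds than this note shows. Statements on the series, on what has been measured and on what is new or still open speak of the compounds shown alone.

Compound 1 `Cc1cc(NC(=O)Nc2ccc(C(C)(C)C)cc2)c2ccccc2n1`: 20000 nM
Compound 2 `CSc1ccc(NC(=O)Nc2cc(C)nc3ccccc23)cc1`: > 25000 nM, a limit
Compound 3 `Cc1cc(NC(=O)Nc2ccccc2C(C)(C)C)c2ccccc2n1`: 22000 nM

In an ADME assay on BJ cells (Homo sapiens) for cytotoxicity, with a stated time of 72 h (a higher number here means that more compound is needed for the effect, a lower number that less compound is needed), compound 1 gives 20000 nM. Compound 2 reaches only a limit of the assay, > 25000 nM. The change between them, (methylsulfanyl in place of tert-butyl on an aromatic carbon), made a step of an at least 1.2-fold higher number from compound 1 to compound 2 (0.09 log units; that floor lies within the scatter); the floor of that step rests on (the limit of > 25000 nM in this assay, at which 1 of the 3 values shown sits). Compound 3 gives 22000 nM in this assay. The difference between the cores of compound 1 and compound 3 is not broken down here; their two values lie within the scatter of each other.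

Compound 4 `CSc1ccccc1NC(=O)Nc1cc(C)nc2ccccc12` is not yet measured. It arises from compound 3 by the same kind of change, (methylsulfanyl in place of tert-butyl on an aromatic carbon), but the place differs: here the group stands ortho to a large group, whereas in compound 2 it stands para to a large group. Compound 4 is therefore expected to move by a 1.2-fold higher number from compound 3 to compound 4 (0.07 log units; within the scatter), an expectation resting on compound 1 and the step of an at least 1.2-fold higher number from compound 1 to compound 2 (0.09 log units; that floor lies within the scatter). Compound 4 is estimated at 26000 nM.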

Compound 4, half-maximal effective concentration in the BJ assay: > 25000 nM
Compound 4 gave a limit, no number; the forecaster's own chance of this, stated with the estimate: 55%; the middle value is on the limit's open side.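

In the BJ assay the change on the core of compound 3 gives an at least 1.1-fold higher number from compound 3 to compound 4 (0.05 log units; that floor lies within the scatter), a floor and not a number: compound 4 gives > 25000 nM as a limit of the assay. Set beside the earlier step, this gives no sign that the change carries differently from one core to the other, yet it does not show that the two cores respond alike: the same change on two cores in the BJ assay, an at least 1.2-fold higher number (0.09 log units; that floor lies within the scatter) from compound 1 to compound 2 and an at least 1.1-fold higher number (0.05 log units; that floor lies within the scatter) from compound 3 to compound 4; the limit leaves it open whether they differ. In a physicochemical assay for solubility, at pH 7.4 (on this read-out lower numbers stand for lower solubility and higher numbers for higher solubility), compound 3 gives 100 nM and compound 4 gives 21000 nM and the same change gives a 210-fold higher number from compound 3 to compound 4 (2.32 log units; beyond the scatter), a large step, but it is read on this one core only.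

Going by these compounds, what the change does in the physicochemical assay on the core of compound 1 stays open. So does how an amine or a longer chain in the same place would read in either assay.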